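The source may report more compounds than this note shows. Statements on the series, on what has been measured and on what is new or still open speak of the compounds shown alone.

Compound 1 `O=C(CSC(=S)N[C@H]1CCOC1=O)Nc1ccc(Cl)cc1`: in a functional assay on SMMC-7721 cells (Homo sapiens) for cytotoxicity, read by MTT assay, with a stated time of 72 h (on this read-out lower numbers stand for stronger inhibition and higher numbers for weaker inhibition), compound 1 gives > 128000 nM, which is a limit of the assay and not a number.
Compound 2 `Cc1ccc(NC(=O)CSC(=S)N[C@H]2CCOC2=O)cc1`: in this assay compound 2 gives 32700 nM.

Among the compounds with values here, compound 2 therefore holds the only real number in this assay; the one other value shown is a limit. Within the data shown here, the single measured step, an at least 3.9-fold lower number from compound 1 to compound 2 (0.59 log units; beyond the scatter), starts from that limit, so its true size is known only as a lower bound. Compound 3 `COc1ccc(NC(=O)CSC(=S)N[C@H]2CCOC2=O)cc1` differs from compound 2 by methoxy in place of methyl on an aromatic carbon. Among the measured compounds shown here, no measured step swaps methyl for methoxy, so the one step between compound 1 and compound 2 gives no direct guidance on this change, and only the position of compound 2 anchors the expectation. A change of this kind is expected to leave the result within the usual scatter, so the estimated step of a 1.2-fold higher number from compound 2 to compound 3 (0.09 log units; within the scatter) is small. Compound 3 is accordingly estimated at 40000 nM in this assay, with a range from 13000 nM to 120000 nM.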

Compound 3, half-maximal inhibitory concentration: > 128000 nM
Compound 3 gave a limit, no number; the forecaster's own chance of this, stated with the estimate: 20%; middle value at least 3.2-fold (0.50 log units) from the limit.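

In this assay, methoxy in place of methyl on an aromatic carbon, para to a large group, gives an at least 3.9-fold higher number from compound 2 to compound 3 (0.59 log units; beyond the scatter), so even this small change at this position has a readable effect. Of the three groups shown here, only the methyl of compound 2 gives a real number, while the chloro of compound 1 and the methoxy of compound 3 each give a limit. The step from chloro to methoxy cannot be read, because neither end of it is a real number: the limit of > 128000 nM in this assay, at which 2 of the 3 values shown sit.

Going by these compounds, how far compound 1 and compound 3 lie past that limit stays open. On these data alone, it is also open whether methyl alone gives a real number here, or whether an ethyl group, a longer chain or an amine at this position would do so too.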